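The source may report more compounds than this note shows. Statements on the series, on what has been measured and on what is new or still open speak of the compounds shown alone.

Compound 1 `O=C1/C(=C/c2cccc([N+](=O)[O-])c2)CN(S(=O)(=O)c2ccc(F)cc2)C/C1=C\c1ccccc1F` gives 17000 nM in an ADME assay on L02 cells (Homo sapiens) for cytotoxicity, read by MTT assay, with a stated time of 24 h; a higher number here means a weaker inhibitor, a lower number a stronger inhibitor. Compound 2 `N#Cc1ccc(/C=C2\CN(S(=O)(=O)c3ccc(F)cc3)C/C(=C\c3ccccc3F)C2=O)cc1` gives 21900 nM in this assay; the change here is 4-cyanophenyl in place of 3-nitrophenyl on a double-bonded chain carbon bound to a double-bonded ring carbon, and the step it made is a 1.3-fold higher number from compound 1 to compound 2 (0.11 log units; within the scatter). Compound 3 `COc1cc(/C=C2\CN(S(=O)(=O)c3ccc(F)cc3)C/C(=C\c3cccc([N+](=O)[O-])c3)C2=O)cc(OC)c1OC` gives 18800 nM in this assay; its core differs from the core of compound 1 by 3,4,5-trimethoxyphenyl in place of 2-fluorophenyl on a double-bonded chain carbon bound to a double-bonded ring carbon, with a step of a 1.1-fold higher number from compound 1 to compound 3 (0.04 log units; within the scatter). Compound 4 `COc1cc(/C=C2\CN(S(=O)(=O)c3ccc(F)cc3)C/C(=C\c3ccc(C#N)cc3)C2=O)cc(OC)c1OC` is not yet measured; relative to compound 3 it carries the same change as seen between compound 1 and compound 2, namely (4-cyanophenyl in place of 3-nitrophenyl on a double-bonded chain carbon bound to a double-bonded ring carbon), at a place described in the same words. The step is expected to be a 1.3-fold higher number from compound 3 to compound 4 (0.11 log units; within the scatter), resting on the earlier step of a 1.3-fold higher number from compound 1 to compound 2 (0.11 log units; within the scatter), which stayed within the scatter. Compound 4 is therefore estimated at 24000 nM, with the expected range running from 12000 nM to 48000 nM.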

Compound 4, half-maximal inhibitory concentration: 12900 nM
Beside the measured number, compound 4's estimate is 1.9-fold (0.27 log units) above it; the range from low to high includes it.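

In this assay, 4-cyanophenyl in place of 3-nitrophenyl gives a 1.5-fold lower number from compound 3 to compound 4 (0.16 log units; within the scatter), and the two readings of this change do not separate: the same change on two cores in this assay, a 1.3-fold higher number (0.11 log units; within the scatter) from compound 1 to compound 2 and a 1.5-fold lower number (0.16 log units; within the scatter) from compound 3 to compound 4, 1.9-fold (0.27 log units) apart, within the scatter of two such steps. Likewise, 3,4,5-trimethoxyphenyl in place of 2-fluorophenyl gives a 1.7-fold lower number from compound 2 to compound 4 (0.23 log units; within the scatter), and these readings do not separate either: the same change on two cores in this assay, a 1.1-fold higher number (0.04 log units; within the scatter) from compound 1 to compound 3 and a 1.7-fold lower number (0.23 log units; within the scatter) from compound 2 to compound 4, 1.9-fold (0.27 log units) apart, within the scatter of two such steps. Both changes thus carry between these cores without a detectable difference, but with every step inside the scatter, this shows neither a real effect of either change nor that any step would hold on another core.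

Open, as far as these compounds go, is whether a carboxylic acid or an amine on a double-bonded chain carbon bound to a double-bonded ring carbon would give a step beyond the scatter.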